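Terminal Chloro on the Amide Chain of a Sulfonate Ester

The compounds below may be only part of what the source reports. "The series", "measured", "known", "first", "only" and "open" are said of these compounds alone.

Compound 1 `CC(C)C(=O)Nc1cccc(S(=O)(=O)Oc2ccccc2C(C)C)c1` gives 16000 nM
Compound 2 `CCCC(=O)Nc1ccc(S(=O)(=O)Oc2ccccc2C(C)C)cc1` gives 950 nM
Compound 3 `CCCC(=O)Nc1ccc(S(=O)(=O)Oc2ccccc2I)cc1` gives 2000 nM

The three compounds were read in a functional assay on HT-1080 cells (Homo sapiens) for antiproliferative activity, read by sulforhodamine B assay, with a stated time of 48 h; on this read-out higher numbers stand for weaker inhibition and lower numbers for stronger inhibition. Compound 2 stands lowest of the three numbers. Its nearest neighbour is compound 3, reached by a single change, with a 2.1-fold higher number from compound 2 to compound 3 (0.32 log units; beyond the scatter). Going by the values given here, compound 1 lies furthest from compound 2, but it differs from compound 2 in more than one place, so its two values show only that compound 1 sits far above compound 2 in this assay.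

Compound 4 `CC(C)c1ccccc1OS(=O)(=O)c1ccc(NC(=O)CCCCl)cc1` is the next compound in line. It differs from compound 2 by chloro in place of hydrogen on a saturated chain carbon, three bonds along the chain from a carbonyl carbon. Among the compounds with values here, none of the measured steps bears directly on this change: the one single-place step, a 2.1-fold higher number from compound 2 to compound 3 (0.32 log units; beyond the scatter), alters a substituent on an aromatic carbon, not the saturated chain of the amide, and compound 1 is separated from compound 2 by several changes at once. With nothing in the measured set speaking for or against the chain-end change, the expected step of a 1.1-fold higher number from compound 2 to compound 4 (0.02 log units; within the scatter) is estimated to fall within the scatter, with no clear direction.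

Compound 4 is therefore expected to give about 1000 nM, estimated between 400 nM and 2500 nM.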

Compound 4, half-maximal inhibitory concentration: 3800 nM
Estimate against measurement, compound 4: 3.8-fold (0.58 log units) below, outside the stated range (above it).
By their numbers in this assay, from the lowest: compound 2; then compounds 3 and 4 (each within the scatter of the next); then compound 1.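

In this assay, the end of the amide chain proves not to be a silent position: chloro in place of hydrogen on a saturated chain carbon, three bonds along the chain from a carbonyl carbon, gives a 4.0-fold higher number from compound 2 to compound 4 (0.60 log units; beyond the scatter). Going by these compounds alone, the earlier single-place step, a 2.1-fold higher number from compound 2 to compound 3 (0.32 log units; beyond the scatter), concerned only a substituent on an aromatic carbon, so this is the first reading of the saturated chain, and it shows that turning propyl into 3-chloropropyl moves the compound towards weaker inhibition by more than the scatter. Nothing measured here accounts for this step, so its origin remains unexplained.

The compounds shown leave open whether the step belongs to chloro itself or would appear with any other group at the chain end, such as a fluoro, a hydroxyl or an amine, or with a longer chain in place of propyl. They also do not tell whether the same change would give a step of similar size on the core of compound 3, which carries iodo in place of isopropyl.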